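This account rests on a few compounds, and the source may have more. Where it says the series, first, only, none or still open, it means among the compounds named here.

Measured in a functional assay on COLO 205 cells (Homo sapiens) for antiproliferative activity, read by MTT assay, with a stated time of 68 h; on this read-out higher numbers stand for weaker inhibition and lower numbers for stronger inhibition:
compound 1, `O=S(=O)(Nc1ccc(F)c(C#Cc2cnc3[nH]ncc3c2)c1F)c1ccccc1`, gives 2100 nM;
compound 2, `O=S(=O)(Nc1ccc(F)c(C#Cc2cnc3[nH]ncc3c2)c1F)c1cccnc1`, gives 445 nM;
compound 3, `O=S(=O)(Nc1ccc(F)c(C#Cc2cnc3ccnn3c2)c1F)c1cccnc1`, gives 1840 nM.

Among these three, compound 2 stands at the lowest number, and its steps to the other two are both beyond the scatter: a 4.7-fold lower number from compound 1 to compound 2 (0.67 log units; beyond the scatter) and a 4.1-fold higher number from compound 2 to compound 3 (0.62 log units; beyond the scatter).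

Compound 4, `O=S(=O)(Nc1ccc(F)c(C#Cc2cnc3[nH]nc(-c4ccncc4)c3c2)c1F)c1cccnc1`, differs from compound 2 by pyridin-4-yl in place of hydrogen on an aromatic carbon. Neither measured step touches this place: the step from compound 1 to compound 2 concerns the group on the sulfonyl sulfur, and the step from compound 2 to compound 3 concerns the ring system on the triple-bonded carbon. Both were modest in size, which suggests that single changes in this series move the number by a moderate amount rather than a large one, but they give no direction for a group added to the five-membered ring of the core.

Within the data shown here, with no direct precedent, compound 4 is expected to stay close to compound 2, with a wide range; the estimated step is a 1.3-fold lower number from compound 2 to compound 4 (0.10 log units; within the scatter). In this assay compound 4 is expected to give about 350 nM, between 80 nM and 1500 nM.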

Compound 4, half-maximal inhibitory concentration: 78 nM
Compound 4: middle estimate off by 4.5-fold (0.65 log units), on the high side, and the stated range ends above it.
By their numbers in this assay, from the lowest: compound 4; then compound 2; then compounds 3 and 1 (each within the scatter of the next).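

In this assay, pyridin-4-yl in place of hydrogen on an aromatic carbon of the five-membered ring brings a 5.7-fold lower number from compound 2 to compound 4 (0.76 log units; beyond the scatter). Among these compounds, this place on the core, which the earlier steps did not touch, therefore takes a six-membered aromatic ring with no loss on this read-out, and the number falls instead. Nothing at hand says why the number falls at this place.

The compounds shown leave open whether the ring nitrogen of pyridin-4-yl matters, which a phenyl group on the same carbon would test, and whether a smaller group such as methyl or an amine would do the same. From the compounds shown here alone, it also remains open whether the same change would lower the number with phenyl rather than pyridin-3-yl on the sulfonyl sulfur.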